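Swapping the aryl group on the urea nitrogen of compound 2

The compounds below may be only part of what the source reports. "The series", "measured", "known", "first", "only" and "open" are said of these compounds alone.

Among the measured compounds shown here, in a functional assay on the whole organism (strain Swiss albino) for inhibition, with Mus musculus as the target, in the writhing test, with a stated time of 30 min, at a dose of 100 mg/kg (a lower number here means less inhibition, a higher number more inhibition at the dose given (going by the name of the read-out)), compound 2 `CCN1CCc2c(c(C(C)(C)C)nn2C(=O)Nc2ccc(Br)cc2)C1` gives 72.8%, the highest of the two numbers known, with compound 1 `CCN1CCc2c(c(C)nn2C(=O)Nc2ccc(Br)cc2)C1` nearest at 59.7%. Compound 3 `CCN1CCc2c(c(C(C)(C)C)nn2C(=O)Nc2ccc(F)cc2F)C1` is still to be measured in this assay. It differs from compound 2 by 2,4-difluorophenyl in place of 4-bromophenyl on an amide-type nitrogen. For the measured compounds named here, the only measured step, a number 13.1 percentage points higher from compound 1 to compound 2 (beyond the scatter), concerns the tert-butyl group and not the aryl ring, so no measured step bears on this change. Compound 3 is therefore expected to give 66% in this assay, within 46% to 84%, a step of a number 6.8 percentage points lower from compound 2 to compound 3 (within the scatter) that is not expected to go beyond the scatter.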

Compound 3, a percentage reported as inhibition, in the whole organism at one dose (the size of the read-out at that dose, not a potency): 71.9%
Compound 3: the middle estimate sits 5.9 percentage points below what was measured; the range from low to high includes it.
By their numbers in this assay, from the lowest: compound 1; then compounds 3 and 2 (each within the scatter of the next).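

On the amide-type nitrogen, 2,4-difluorophenyl in place of 4-bromophenyl gives a number 0.9 percentage points lower from compound 2 to compound 3 (within the scatter) in this assay. Among the compounds shown here, this is the first measured exchange at this position, and it shows that, with tert-butyl held in place, one halogen-bearing phenyl ring can replace another without leaving the scatter at this dose. From the compounds shown here alone, whether a phenyl ring carrying a methoxy group or an amine, or a pyridine ring, would read the same remains open. Nothing measured here gives a reason why these two rings read alike.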